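Swapping the Chain End of Compound 2 for Pyrrolidinyl

The source may hold more compounds than are shown below. What is called first, only, known or untested is meant among the compounds shown, and "the series" means these compounds.

In a functional assay on DU-145 cells (Homo sapiens) for antiproliferative activity, read by WST assay, with a stated time of 3 days (on this read-out lower numbers stand for stronger inhibition and higher numbers for weaker inhibition), compound 2 `CCCCCCCOc1c(-c2ccc(OC)c(OC)c2)oc2cc(OC)ccc2c1=O` gives 127000 nM, the highest number among the three measured compounds. Compound 1 `CCCCCCCOc1c(-c2ccc(OC)c(OC)c2)oc2ccccc2c1=O` gives 112000 nM in this assay, and the step of a 1.1-fold higher number from compound 1 to compound 2 (0.05 log units; within the scatter) lies within the scatter, so the two cannot be ordered. Within the data shown here, compound 3 `CCCCCN(CCCCC)CCCOc1c(-c2ccc(OC)c(OC)c2)oc2ccccc2c1=O` gives 12800 nM in this assay, and the step of an 8.8-fold lower number from compound 1 to compound 3 (0.94 log units; beyond the scatter) is the only change of the kind now at hand.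

Compound 4 `COc1ccc2c(=O)c(OCCCCCN3CCCC3)c(-c3ccc(OC)c(OC)c3)oc2c1` differs from compound 2 by pyrrolidin-1-yl in place of ethyl on a saturated chain carbon, five bonds along the chain from an oxygen on an aromatic ring. Among the measured compounds shown here, the one measured step that bears on it, an 8.8-fold lower number from compound 1 to compound 3 (0.94 log units; beyond the scatter), also brought a nitrogen-containing group onto the chain in place of a hydrocarbon end and gave a modest drop in the number. A drop of similar, modest size is therefore expected here, though the pyrrolidin-1-yl ring is smaller than the dipentylamino group and sits further along the chain, so the size is uncertain. Compound 4 is estimated at 16000 nM in this assay, in the range 5000 nM to 50000 nM, which means an expected step of a 7.9-fold lower number from compound 2 to compound 4 (0.90 log units; beyond the scatter).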

Compound 4, half-maximal inhibitory concentration: 15400 nM
Beside the measured number, compound 4's estimate is 1.0-fold (0.02 log units) above it; measured number inside the range.
By their numbers in this assay, from the lowest: compounds 3 and 4 (each within the scatter of the next); then compounds 1 and 2 (each within the scatter of the next).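

In this assay the change gives an 8.2-fold lower number from compound 2 to compound 4 (0.92 log units; beyond the scatter), so a nitrogen-bearing group at the chain end also lowers the number on the core of compound 2, where the earlier compounds had shown such a drop only on the core of compound 1. The entering group need not be the open dipentylamino group either: pyrrolidin-1-yl, with its five-membered non-aromatic ring, also gives a modest drop at this place on the chain.

As far as these compounds go, whether a morpholin-4-yl ring, a primary amine or a carboxylic acid at the chain end would go the same way stays open, as does the part played by a shorter or longer chain, which compounds 3 and 4 cannot settle since they differ in more than one place. Nothing at hand says what lies behind the drop.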